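The source may hold more compounds than are shown below. What is called first, only, known or untested is meant among the compounds shown, and "the series" means these compounds.

Working notes on the hydroxyalkyl-triazole series in an assay on isolated protein for inhibition of Indoleamine 2,3-dioxygenase 1 (Homo sapiens); a higher number here means a weaker inhibitor, a lower number a stronger inhibitor. Compound 1 `OCCc1cn(CCNc2nonc2/C(=N/O)Nc2ccc(F)c(Br)c2)nn1` gives 247 nM; compound 2 `OCCCc1cn(CCNc2nonc2/C(=N/O)Nc2ccc(F)c(Br)c2)nn1` gives 98 nM; compound 3 `CC(O)c1cn(CCNc2nonc2/C(=N/O)Nc2ccc(F)c(Br)c2)nn1` gives 53 nM. Compound 3 sits at the low end of the three: the step of a 4.7-fold lower number from compound 1 to compound 3 (0.67 log units; beyond the scatter) is beyond the scatter, whereas a 1.8-fold lower number from compound 2 to compound 3 (0.27 log units; within the scatter) is within it. Compound 4 `CC(C)(O)c1cn(CCNc2nonc2/C(=N/O)Nc2ccc(F)c(Br)c2)nn1` carries methyl in place of hydrogen on a saturated chain carbon bound to an aromatic carbon, an oxygen on a saturated carbon and a saturated chain carbon. Within the data shown here, no measured pair isolates this change; the steps of a 2.5-fold lower number from compound 1 to compound 2 (0.40 log units; beyond the scatter) and a 4.7-fold lower number from compound 1 to compound 3 (0.67 log units; beyond the scatter) only show that reshaping the hydroxyalkyl group moves the number modestly, and the values of compound 2 and compound 3 show little separation. A step of at most modest size in this assay is therefore expected, direction uncertain. Compound 4 is expected at 45 nM, range 15 nM to 140 nM, an expected step of a 1.2-fold lower number from compound 3 to compound 4 (0.07 log units; within the scatter).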

Compound 4, half-maximal inhibitory concentration: 115 nM
Compound 4: the middle estimate sits 2.6-fold (0.41 log units) below what was measured; the range from low to high includes it.
By their numbers in this assay, from the lowest: compounds 3, 2 and 4 (each within the scatter of the next, the first and the last beyond it); then compound 1.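

Methyl in place of hydrogen on the saturated chain carbon bound to an aromatic carbon and an oxygen gives the first single-change reading at this carbon in this assay, and it is a modest step in the unfavourable direction (a 2.2-fold higher number from compound 3 to compound 4 (0.34 log units; beyond the scatter)). The 1-hydroxy-1-methylethyl group stays level with 3-hydroxypropyl (a 1.2-fold higher number from compound 2 to compound 4 (0.07 log units; within the scatter)) and keeps a modest edge over 2-hydroxyethyl (a 2.1-fold lower number from compound 1 to compound 4 (0.33 log units; beyond the scatter)). Nothing at hand explains the methyl step. Still open, as far as these compounds go, is how this carbon responds to a larger group such as ethyl in place of that methyl. Also open, from the compounds shown here alone, is whether the hydroxy itself is needed, which an amine or a methoxy group at the same carbon would test.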